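Benzylamine series: removing the N-methyl from compound 3

The source may report more compounds than this note shows. Statements on the series, on what has been measured and on what is new or still open speak of the compounds shown alone.

Measured compounds in a functional assay on HPAC cells (Homo sapiens) for inhibition, read by MTT assay, with a stated time of 72 h; a lower number here means a stronger inhibitor of growth, a higher number a weaker inhibitor of growth:
- compound 1 `O=S(=O)(NCCCNCc1ccc(Cl)c(C(F)(F)F)c1)c1cc(C(F)(F)F)cc(C(F)(F)F)c1` gives 3000 nM
- compound 2 `O=S(=O)(NCCCNCc1ccc(C(F)(F)F)cc1)c1cc(C(F)(F)F)cc(C(F)(F)F)c1` gives 2700 nM
- compound 3 `CN(CCCNS(=O)(=O)c1cc(C(F)(F)F)cc(C(F)(F)F)c1)Cc1ccccc1` gives 30000 nM

Compound 3 has the highest number of the three in this assay. Its nearest neighbour is compound 1, and compound 2 lies furthest, both with lower numbers than compound 3. Both gaps are beyond the scatter.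

Compound 4 `O=S(=O)(NCCCNCc1ccccc1)c1cc(C(F)(F)F)cc(C(F)(F)F)c1` differs from compound 3 in one place: hydrogen in place of methyl on an amine nitrogen. Compound 4 is otherwise the same chain and the same core as compound 3.

For the measured compounds named here, only one single-place step has been measured, a 1.1-fold lower number from compound 1 to compound 2 (0.05 log units; within the scatter), and it concerns the aryl group on the saturated chain carbon, not the amine nitrogen. It gives no guidance on the change from compound 3 to compound 4. What the values do show is that compound 1 and compound 2, which both carry a hydrogen on the amine nitrogen, sit well below compound 3 in this assay, although they also differ from compound 3 at the aryl group, so the amine change cannot be separated from the aryl change.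

On that basis a lower number is expected for compound 4 than for compound 3, with a 6.0-fold lower number from compound 3 to compound 4 (0.78 log units; beyond the scatter) as the estimated step, and a wide range to reflect the missing direct comparison. The estimate for compound 4 in this assay is 5000 nM, within 1500 nM to 16000 nM.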

Compound 4, concentration for 50% growth inhibition: 3200 nM
Compound 4: middle estimate off by 1.6-fold (0.19 log units), on the high side, and the stated range covers the measured number.
By their numbers in this assay, from the lowest: compounds 2, 1 and 4 (each within the scatter of the next); then compound 3.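

In this assay, for the compounds shown here, the amine nitrogen can now be read on its own: a 9.4-fold lower number from compound 3 to compound 4 (0.97 log units; beyond the scatter), with hydrogen in place of methyl as the only change, so the gap seen for compound 3 does not depend on any aryl difference. The aryl group carries little in this set, with a 1.2-fold higher number from compound 2 to compound 4 (0.07 log units; within the scatter) and a 1.1-fold higher number from compound 1 to compound 4 (0.03 log units; within the scatter), both within the scatter, so phenyl, 4-(trifluoromethyl)phenyl and 4-chloro-3-(trifluoromethyl)phenyl cannot be told apart while the amine nitrogen carries hydrogen. Nothing measured here accounts for the step at the amine nitrogen.

Still open, on these data alone, is whether methyl on the amine nitrogen gives a step of the same size when the aryl group is 4-(trifluoromethyl)phenyl or 4-chloro-3-(trifluoromethyl)phenyl, and how an ethyl or an acetyl group on that nitrogen would read in this assay. Also open, as far as these compounds go, is whether the indifference to the aryl group would hold with a longer chain in place of the present one, or with a pyridine ring in place of the phenyl ring.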